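Compound 3 against the limit in the series

The source may hold more compounds than are shown below. What is called first, only, known or untested is meant among the compounds shown, and "the series" means these compounds.

In an ADME assay on HEK293 cells (Homo sapiens) for cytotoxicity, with a stated time of 72 h (on this read-out higher numbers stand for an effect only at larger amounts of compound and lower numbers for an effect already at smaller amounts), compound 1 `C=C[C@@](C)(/C=C/c1ccc(Nc2ccc(OC)c(F)c2)cc1)CCC=C(C)C` gives > 36600 nM as a limit of the assay and not a number. Compound 2 `C=C[C@@](C)(/C=C/c1ccc(Nc2ccc(Cl)c(F)c2)cc1)CCC=C(C)C` gives > 36600 nM as a limit too, so it stands without a readable number. The picture so far is the limit of > 36600 nM in this assay, at which 2 of the 2 values shown sit, with no number among the results. Compound 3 `C=C[C@@](C)(/C=C/c1ccc(Nc2cc(F)c(F)c(F)c2)cc1)CCC=C(C)C` is reached from compound 2 through 3,4,5-trifluorophenyl in place of 4-chloro-3-fluorophenyl on a nitrogen on an aromatic ring with the rest of the core unchanged. Going by the values given here, the only measured step, a step that the two limits leave unreadable from compound 1 to compound 2 for chloro in place of methoxy on an aromatic carbon, has no size to carry over. No step beyond the scatter is therefore expected in this assay and no direction can be named. The step expected is a step that the limit leaves unreadable from compound 2 to compound 3 on this estimate. Compound 3 is expected at 40000 nM with an estimated range of 20000 nM to 80000 nM and may well come out only as a limit.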

Compound 3, half-maximal effective concentration: > 36600 nM
Compound 3: only a limit was reported; the forecaster's own chance of this, stated with the estimate: 80%; the middle value is on the limit's open side.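

No step can be read among compound 1, compound 2 and compound 3 in this assay, as all three give only a limit of the assay and not a number: the limit of > 36600 nM in this assay, at which 3 of the 3 values shown sit.

From the compounds shown here alone, whether the 3-fluoro-4-methoxyphenyl, 4-chloro-3-fluorophenyl and 3,4,5-trifluorophenyl groups differ at all in this read-out remains open.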